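The source may report more compounds than this note shows. Statements on the series, on what has been measured and on what is new or still open speak of the compounds shown alone.

Measured compounds:
compound 1 `COC(=O)[C@@]1(C)CCC=C2[C@@H]1CC[C@@H](C)[C@]2(C)Cc1c[nH]c2ccccc12` — 4200 nM
compound 2 `COC(=O)[C@@]1(C)CCC=C2[C@@H]1CC[C@@H](C)[C@]2(C)Cc1c[nH]c2ccc(C)cc12` — 20000 nM

In a functional assay on T47D cells (Homo sapiens) for inhibition, read by sulforhodamine B assay, with a stated time of 48 h (a higher number here means a weaker inhibitor of growth, a lower number a stronger inhibitor of growth), compound 1 gives 4200 nM. In the same assay compound 2 gives 20000 nM. Compound 2 stands as the highest of the two numbers; its nearest neighbour is compound 1, and the step of a 4.8-fold higher number from compound 1 to compound 2 (0.68 log units; beyond the scatter) lies beyond the scatter.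

Compound 3 `COC(=O)[C@@]1(C)CCC=C2[C@@H]1CC[C@@H](C)[C@]2(C)Cc1c[nH]c2ccc(Br)cc12` differs from compound 2 by bromo in place of methyl on an aromatic carbon. Among the compounds with values here, the only measured step, a 4.8-fold higher number from compound 1 to compound 2 (0.68 log units; beyond the scatter), concerns methyl entering in place of hydrogen at this aromatic carbon; it does not cover bromo in place of methyl, and no other step among the measured compounds bears on the change. The two groups are alike in what is counted: neither adds a ring, a donor, an acceptor or a charge. With nothing measured to set the size of the step in this assay, the working expectation is a step that stays within the scatter, in either direction, with a modest move not excluded. Compound 3 is therefore estimated at 15000 nM, with a range from 5000 nM to 45000 nM. The expected step is a 1.3-fold lower number from compound 2 to compound 3 (0.12 log units; within the scatter).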

Compound 3, concentration for 50% growth inhibition: 16000 nM
Compound 3: the middle estimate sits 1.1-fold (0.03 log units) below what was measured; measured number inside the range.
By their numbers in this assay, from the lowest: compound 1; then compounds 3 and 2 (each within the scatter of the next).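

In this assay, bromo in place of methyl on this aromatic carbon gives a 1.3-fold lower number from compound 2 to compound 3 (0.10 log units; within the scatter) and so does not separate the two groups, which a single substituted compound could not show. Bromo in place of hydrogen gives a 3.8-fold higher number from compound 1 to compound 3 (0.58 log units; beyond the scatter), in the same direction as a 4.8-fold higher number from compound 1 to compound 2 (0.68 log units; beyond the scatter), so both groups on this carbon leave the number higher than the unsubstituted compound 1 and neither compound goes against this within the three shown. Nothing available accounts for the two groups reading alike.

From the compounds shown here alone, whether a hydroxyl, an amine or a carboxylic acid on this carbon would read like methyl and bromo remains open, as does whether any group here can give a lower number than compound 1, which gives 4200 nM. The methyl ester on the shared core is the same in all three compounds, so the effect of a carboxylic acid or an amide at that place is a separate open question.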